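Azido in Place of Chloro on Compound 3

This account rests on a few compounds, and the source may have more. Where it says the series, first, only, none or still open, it means among the compounds named here.

Three compounds have been measured in a functional assay on MCF7 cells (Homo sapiens) for antiproliferative activity, read by MTT assay, with a stated time of 48 h; a higher number here means a weaker inhibitor, a lower number a stronger inhibitor:
compound 1 `CC(=O)O[C@]1(C)/C=C/C(=O)/C(CO)=C\C[C@](C)(CCC=C(C)C)/C=C/[C@H]1OC(=O)C=C(C)C`, 2320 nM
compound 2 `C=C1/C=C/C(=O)/C(CO)=C\C[C@](C)(CCC=C(C)C)/C=C/[C@H]1OC(=O)C=C(C)C`, 2750 nM
compound 3 `CC(C)=CCC[C@]1(C)/C=C/[C@@H](OC(=O)C=C(C)C)[C@](C)(O)/C=C/C(=O)/C(CCl)=C\C1`, 610 nM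

Compound 3 stands lowest of the three numbers. Compound 1 is nearest and compound 2 furthest, and both gaps lie beyond the scatter, so compound 3 is the strongest inhibitor among those measured.

Compound 4 `CC(C)=CCC[C@]1(C)/C=C/[C@@H](OC(=O)C=C(C)C)[C@](C)(O)/C=C/C(=O)/C(CN=[N+]=[N-])=C\C1` differs from compound 3 in one place: azido in place of chloro on a saturated chain carbon bound to a double-bonded ring carbon. Within the data shown here, no measured pair shows this change, so its size is not known from the data. In this assay the step from compound 3 to compound 4 is expected to be small, a 1.5-fold higher number from compound 3 to compound 4 (0.17 log units; within the scatter), leaning toward a weaker inhibitor but likely within the scatter. Compound 4 is therefore estimated at 900 nM, with a range from 300 nM to 2700 nM.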

Compound 4, half-maximal inhibitory concentration: 4890 nM
Estimate against measurement, compound 4: 5.4-fold (0.74 log units) below; measured number outside the range, above it.
By their numbers in this assay, from the lowest: compound 3; then compounds 1, 2 and 4 (each within the scatter of the next, the first and the last beyond it).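

In this assay, among these compounds, the change from chloromethyl to azidomethyl gives an 8.0-fold higher number from compound 3 to compound 4 (0.90 log units; beyond the scatter) and provides the first step in this set that can be read at a single place. It shows that the number responds to the group carried on a saturated chain carbon bound to a double-bonded ring carbon, and that azido does not match chloro there. Nothing available explains the shift.

The compounds shown leave open whether bromo or an amine at this place would stay close to compound 3 or to compound 4.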